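The source may hold more compounds than are shown below. What is called first, only, known or untested is meant among the compounds shown, and "the series" means these compounds.

Compound 1: `CC(=O)N1CCN(c2cc(C)cc(-c3cc(Cl)c4c(N)ncnn34)c2)C(=O)C1(C)C` — 92%
Compound 2: `CC(=O)N1CCN(c2cc(-c3cc(Cl)c4c(N)ncnn34)ccc2C(F)(F)F)C(=O)C1(C)C` — 95%

In an ADME assay on microsomes from liver (Homo sapiens) for metabolic stability, read by LC-MS, using NADPH, with stated times of 6 min and 10 min, tested at 0.5 uM (on this read-out lower numbers stand for a less stable compound and higher numbers for a more stable compound), compound 2 gives 95%, the higher of the two numbers, while compound 1 gives 92%; the gap between them lies within the scatter, so the two stand together. Compound 3 is `CC(=O)N1CCN(c2cc(-c3cc(Cl)c4c(N)ncnn34)ccc2S(C)(=O)=O)C(=O)C1(C)C`. Its change from compound 2 is methylsulfonyl in place of trifluoromethyl on an aromatic carbon, on an aromatic carbon of a six-membered aromatic ring of carbon only, ortho to a large group and para to a large group. With both measured compounds sitting high, the step is expected to be a number 2 percentage points lower from compound 2 to compound 3 (within the scatter), none beyond the scatter. Compound 3 is therefore estimated at 93%, between 82% and 99%.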

Compound 3, percent of the compound remaining: 100%
Compound 3: middle estimate off by 7 percentage points, on the low side; measured number outside the range, above it.
By their numbers in this assay, from the lowest: compounds 1, 2 and 3 (each within the scatter of the next).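

In this assay methylsulfonyl in place of trifluoromethyl gives a number 5 percentage points higher from compound 2 to compound 3 (within the scatter) on this aromatic carbon, ortho to a large group and para to a large group. This is the only single-place comparison among the compounds shown, and it places a group with hydrogen-bond acceptors where one without them stood, with no step beyond the scatter. Nothing measured here accounts for the result.
From the compounds shown here alone, whether an amine or a carboxylic acid on this aromatic carbon would keep the percent remaining this high stays open. So does the outcome of the same replacement in a less stable compound.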